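A few compounds are considered here, and "the series" means these few. Any claim that something is new, unique, unknown or untested is made for them only; others in the source may bear on it.

Compound 1 `CCCOC(=O)c1c(C)coc1-c1ccc2c(CC)cccc2c1OC`: in a functional assay on MDA-MB-231 cells (Homo sapiens) for cytotoxicity, read by MTT assay, with a stated time of 72 h (a lower number here means that less compound is needed, a higher number that more compound is needed for the effect), compound 1 reaches only a limit, > 10 ug/mL.
Compound 2 `CCc1cccc2c(OC)c(-c3occ(C)c3COC)ccc12`: in this assay compound 2 gives 9.7 ug/mL.

Among the compounds with values here, compound 2 thus holds the only actual number; the other result is a limit (the limit of > 10 ug/mL in this assay, at which 1 of the 2 values shown sits). Within the data shown here, the sole measured comparison is an at least 1.0-fold lower number from compound 1 to compound 2 (0.01 log units; that floor lies within the scatter), which stays within the scatter. Compound 3 `CCc1cccc2c(OC)c(-c3occ(C)c3COC(=O)CCN(CC)CC)ccc12` differs from compound 2 by (2-(diethylamino)ethyl)carbonyl in place of methyl on an oxygen on a saturated carbon. Among the measured compounds shown here, no measured step touches this position, so the change has no precedent here. The expected step is therefore a 1.2-fold lower number from compound 2 to compound 3 (0.08 log units; within the scatter), within the scatter. For compound 3 the estimate is 8 ug/mL, with a range from 3 ug/mL to 25 ug/mL.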

Compound 3, concentration for half-maximal effect: 1.7 ug/mL
For compound 3 the middle estimate is 4.7-fold (0.67 log units) above the measured one, and the stated range ends above it.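

In this assay, the methyl on the oxygen proves not to be a fixed part of the series: (2-(diethylamino)ethyl)carbonyl in its place gives a 5.7-fold lower number from compound 2 to compound 3 (0.76 log units; beyond the scatter) and is the first step shown that clears the scatter. The entering group brings a carbonyl and a nitrogen together, so this one step cannot separate their contributions. No measured property shown here accounts for the step.

Still open, on these data alone, is which part of the new group matters. An acetyl group would test the carbonyl alone, and a morpholine in place of the diethylamino group would test the amine.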